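Ortho substitution on the benzyl group: methyl to trifluoromethyl

This account rests on a few compounds, and the source may have more. Where it says the series, first, only, none or still open, it means among the compounds named here.

Measured in a functional assay on A-375 cells (Homo sapiens) for antiproliferative activity, read by MTT assay, with a stated time of 24 h; on this read-out higher numbers stand for weaker inhibition and lower numbers for stronger inhibition:
- compound 1 `COc1cc(OC)c(-c2coc3cc(OCc4ccccc4)ccc3c2=O)cc1OC`: 1640 nM
- compound 2 `COc1cc(OC)c(-c2coc3cc(OCc4ccccc4C)ccc3c2=O)cc1OC`: 1360 nM

For the measured compounds named here, compound 2 stands at 1360 nM, and its only measured neighbour cannot be told apart from it on these numbers. The next structure is compound 3 `COc1cc(OC)c(-c2coc3cc(OCc4ccccc4C(F)(F)F)ccc3c2=O)cc1OC`, reached through trifluoromethyl in place of methyl on an aromatic carbon, ortho to a large group. Going by the values given here, only one measured step bears on this change: methyl in place of hydrogen on an aromatic carbon, a 1.2-fold lower number from compound 1 to compound 2 (0.08 log units; within the scatter). Among the compounds with values here, no compound with trifluoromethyl has been measured yet, so the support is thin. Given that small step, no shift beyond the scatter is expected in this assay, in either direction. The expected change is a 1.0-fold lower number from compound 2 to compound 3 (0.02 log units; within the scatter). For compound 3 the estimated value is 1300 nM, with an expected range of 600 nM to 2800 nM.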

Compound 3, half-maximal inhibitory concentration: > 10000 nM
Compound 3 gave a limit, no number; the forecaster's own chance of this, stated with the estimate: 3%; middle value at least 7.6-fold (0.88 log units) from the limit.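

In this assay compound 3 sits at a limit of the assay, not a number: the limit of > 10000 nM in this assay, at which 1 of the 3 values shown sits. This aromatic carbon, ortho to a large group, is therefore not indifferent to its substituent: trifluoromethyl gives an at least 7.3-fold higher number from compound 2 to compound 3 (0.86 log units; beyond the scatter), and against the unsubstituted benzyl it gives an at least 6.0-fold higher number from compound 1 to compound 3 (0.78 log units; beyond the scatter). Methyl alone gave no sign of this sensitivity, so the step from hydrogen to methyl does not predict the step to trifluoromethyl, and both new steps bound the loss from one side only.

Going by these compounds, the true size of the loss stays open, as does the feature of trifluoromethyl that matters, which a single change in group cannot separate. Chlorine, methoxy or an amine at this carbon would show whether the sharp drop belongs to trifluoromethyl alone.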